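Methoxy entering the core of compound 1: cytotoxicity outlook

The compounds below may be only part of what the source reports. "The series", "measured", "known", "first", "only" and "open" are said of these compounds alone.

Compound 1 `Cc1nc(C)c(C(=O)Oc2ccccc2/C=C/C(=O)O)nc1C` is the reference point of this set. For the measured compounds named here, in a functional assay on EA.hy 926 cells (Homo sapiens) for cytotoxicity, read by MTT assay, with stated times of 24 h and 12 h, tested at 100 uM (a higher number here means a stronger effect of the compound at the concentration tested, a lower number a weaker effect), compound 1 gives 80.1%, the highest of the three numbers measured so far; compound 3 `COc1cc(/C=C/C(=O)O)ccc1OC(=O)c1nc(C)c(C)nc1C` lies lower, at 55.4%, and compound 2 `COc1ccc(/C=C/C(=O)O)c(OC(=O)c2nc(C)c(C)nc2C)c1` lies furthest away at 18%; both of these gaps from compound 1 exceed the scatter.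

The change leading to compound 4 `COc1ccc(OC(=O)c2nc(C)c(C)nc2C)c(/C=C/C(=O)O)c1` is methoxy in place of hydrogen on an aromatic carbon. Going by the values given here, one measured step bears directly on it: the same kind of change, methoxy in place of hydrogen on an aromatic carbon, gives a number 62.1 percentage points lower from compound 1 to compound 2 (beyond the scatter). Among the compounds with values here, compound 3 also carries a methoxy on its aromatic ring and sits lower than compound 1, but no single-place step connects these two compounds, so only their two values can be compared. Both methoxy-bearing compounds thus fall below compound 1, while the size of the fall differs widely between them, and compound 4 puts its methoxy meta to the 2-carboxyethenyl group and para to a large group, a placement shared by neither compound 2 nor compound 3. A downward step of intermediate size is therefore expected, namely a number 38.1 percentage points lower from compound 1 to compound 4 (beyond the scatter). Compound 4 is estimated at 42%, with a range from 15% to 70%.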

Compound 4, a percentage reported as activity, at one concentration (the size of the read-out at that concentration, not a potency): 79.2%
Compound 4: middle estimate off by 37.2 percentage points, on the low side; measured number above the stated range.
By their numbers in this assay, from the lowest: compound 2; then compound 3; then compounds 4 and 1 (each within the scatter of the next).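

In this assay, methoxy in place of hydrogen on an aromatic carbon does not by itself bring the read-out down: placed meta to a 2-carboxyethenyl group and para to a large group, it gives a number 0.9 percentage points lower from compound 1 to compound 4 (within the scatter) and leaves compound 4 level with compound 1. The same kind of change at a different aromatic carbon gives a number 62.1 percentage points lower from compound 1 to compound 2 (beyond the scatter) in the same assay, so across these two steps the outcome depends on where the methoxy stands and not merely on its presence. No measurement among those shown explains why the two positions differ.

As far as these compounds go, whether this position would also stay level with compound 1 when carrying a hydroxyl group, an amine or a longer ether chain such as ethoxy remains open, so the result cannot yet be extended beyond methoxy. Each read-out also comes from a single concentration, which leaves open whether compound 1 and compound 4 would still match at lower concentrations.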